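Replacing 2-fluorophenyl with 3-chlorophenyl in compound 4

This account rests on a few compounds, and the source may have more. Where it says the series, first, only, none or still open, it means among the compounds named here.

Measured in a functional assay on A-375 cells (Homo sapiens) for cytotoxicity, read by CCK-8 assay, with a stated time of 24 h; on this read-out higher numbers stand for weaker inhibition and lower numbers for stronger inhibition:
Compound 1 `COc1ccccc1Oc1c(N)nc(-c2ccccc2)nc1Cl`: 7220 nM
Compound 2 `COc1ccccc1Oc1c(N)nc(-c2cccc(C)c2)nc1Cl`: 65300 nM
Compound 3 `COc1ccccc1Oc1c(N)nc(-c2ccccc2F)nc1Cl`: > 80000 nM (a limit of the assay, not a number)

The entry for compound 3, > 80000 nM, is a limit of the assay and not a number. Only compound 3 in this short series sits at that limit, so any step starting from it has one open end.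

Compound 4 `COc1ccccc1Oc1c(N)nc(-c2cccc(Cl)c2)nc1Cl` is still unmeasured. It differs from compound 3 as follows: 3-chlorophenyl in place of 2-fluorophenyl on an aromatic carbon. In words, 3-chlorophenyl stands in place of 2-fluorophenyl on an aromatic carbon.

Within the data shown here, three measured steps bear on this change. Methyl in place of hydrogen gave a 9.0-fold higher number from compound 1 to compound 2 (0.96 log units; beyond the scatter), a modest step. Fluoro in place of hydrogen gave an at least 11-fold higher number from compound 1 to compound 3 (1.04 log units; beyond the scatter), a large one. The remaining comparison, an at least 1.2-fold higher number from compound 2 to compound 3 (0.08 log units; that floor lies within the scatter), does not separate the two substituted compounds. Both substituents moved the number upward, and compound 2, with 3-methylphenyl, is the closest guide for 3-chlorophenyl at 65300 nM.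

In this assay a small step toward a lower number is therefore expected, with no full return to the level of compound 1. The estimate for this change is an at least 2.0-fold lower number from compound 3 to compound 4 (0.30 log units; that floor lies within the scatter). Compound 4 is expected at 40000 nM, with an estimated range of 15000 nM to 90000 nM.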

Compound 4, half-maximal inhibitory concentration: 38300 nM
The estimate for compound 4 lay 1.0-fold (0.02 log units) above the measured number; the measured number falls inside the stated range.
By their numbers in this assay, from the lowest: compound 1; then compounds 4 and 2 (each within the scatter of the next). At a limit, above all of these: compound 3.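

In this assay, the 3-chlorophenyl group gives a 5.3-fold higher number from compound 1 to compound 4 (0.72 log units; beyond the scatter), so it joins the other substituted rings in lying above the plain phenyl of compound 1, while the swap of methyl for chloro gives a 1.7-fold lower number from compound 2 to compound 4 (0.23 log units; within the scatter), which leaves the 3-chlorophenyl and 3-methylphenyl groups not told apart. The change at this position also gives an at least 2.0-fold lower number from compound 3 to compound 4 (0.31 log units; beyond the scatter), which shows that a substituted phenyl here can return a measurable number where the 2-fluorophenyl group did not, although the halogen and its place on the ring change together in this step. The entry for compound 3 is a limit of the assay and not a number, so the full size of that step stays unknown: the limit of > 80000 nM in this assay, at which 1 of the 4 values shown sits.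

The compounds shown do not separate the effect of the halogen from that of its place on the ring, a question that 3-fluorophenyl and 2-chlorophenyl groups would address. As far as these compounds go, it also remains open whether a group of another kind on this ring, such as an amine or a carboxylic acid, would give a number lower than that of compound 1.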